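The source may report more compounds than this note shows. Statements on the series, on what has been measured and on what is new or still open speak of the compounds shown alone.

Working notes on the series in an ADME assay on microsomes from liver (Rattus norvegicus) for metabolic stability; on this read-out lower numbers stand for a shorter-lived compound and higher numbers for a longer-lived compound. Compound 1 `CC(C)C(Cc1nnn[nH]1)c1ccc(-c2ccc3cccc(F)c3c2)[nH]c1=O` gives 2.08 h in this assay. Compound 2 `CC(C)C(/C=C1/CCNC1=O)c1ccc(-c2ccc3cccc(F)c3c2)[nH]c1=O` gives 0.06 h in this assay; the step between them is a 35-fold lower number from compound 1 to compound 2 (1.54 log units; beyond the scatter). Compound 3 `Cc1nc(C(c2ccc(-c3ccc4cccc(F)c4c3)[nH]c2=O)C(C)C)[nH]c1C` gives 0.0733 h in this assay. The corresponding step reads a 28-fold lower number from compound 1 to compound 3 (1.45 log units; beyond the scatter), and against the other ring replacement a 1.2-fold higher number from compound 2 to compound 3 (0.09 log units; within the scatter). Compound 3 therefore stands second highest of the three numbers, with compound 2 within the scatter of it and compound 1 far above.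

Compound 4 `Cc1c[nH]c(C(c2ccc(-c3ccc4cccc(F)c4c3)[nH]c2=O)C(C)C)n1` is not yet measured in this assay. It differs from compound 3 by hydrogen in place of methyl on an aromatic carbon. None of the three measured steps bears directly on this change: each of those exchanged the whole five-membered ring on the saturated chain carbon, and the two large ones, a 35-fold lower number from compound 1 to compound 2 (1.54 log units; beyond the scatter) and a 28-fold lower number from compound 1 to compound 3 (1.45 log units; beyond the scatter), both start from the compound bearing the (1H-tetrazol-5-yl)methyl group. Between the two imidazole- or lactam-bearing compounds the step was a 1.2-fold higher number from compound 2 to compound 3 (0.09 log units; within the scatter), within the scatter. Removing a single methyl from the ring is a far smaller change than any of these, so no step beyond the scatter is expected. The step from compound 3 is estimated as a 1.1-fold higher number from compound 3 to compound 4 (0.04 log units; within the scatter). Compound 4 is accordingly expected at 0.08 h, with a range from 0.03 h to 0.2 h.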

Compound 4, half-life: < 0.0667 h
Compound 4 ended at the assay's limit (the forecaster's own chance of this, stated with the estimate: 5%); at least 1.1-fold (0.07 log units) between middle value and limit.
By their numbers in this assay, from the lowest: compounds 2 and 3 (each within the scatter of the next); then compound 1.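

Compound 4 gives < 0.0667 h in this assay, which is a limit of the assay and not a number: the limit of < 0.0667 h in this assay, at which 1 of the 4 values shown sits.

This is the first read on the aromatic carbon of the imidazole ring, and hydrogen in place of methyl there brings no gain in half-life, although an at least 1.0-fold lower number from compound 3 to compound 4 (0.04 log units; that floor lies within the scatter) has a floor that lies within the scatter, so no real loss is shown either. With only one methyl left on the ring, the gap to the tetrazole compound stays large, at an at least 31-fold lower number from compound 1 to compound 4 (1.49 log units; beyond the scatter), while the step from compound 2 cannot be read at this limit.

From the compounds shown here alone, how far compound 4 lies beneath its limit stays open, and with it the true size of the step from compound 3. This aromatic carbon carries only methyl or hydrogen in the compounds shown, so the effect on half-life of a chlorine atom, a trifluoromethyl group or a hydroxymethyl group in that place remains unknown.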